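Quinone for hydroquinone on a pyrazole core, second instance

The source may report more compounds than this note shows. Statements on the series, on what has been measured and on what is new or still open speak of the compounds shown alone.

Measured compounds:
Compound 1 `NS(=O)(=O)c1ccc(-n2nc(-c3ccc(Cl)cc3)cc2-c2cc(O)ccc2O)cc1`: 5030 nM
Compound 2 `CC(=O)NS(=O)(=O)c1ccc(-n2nc(-c3ccccc3)cc2-c2cc(O)ccc2O)cc1`: 93600 nM
Compound 3 `NS(=O)(=O)c1ccc(-n2nc(-c3ccc(Cl)cc3)cc2C2=CC(=O)C=CC2=O)cc1`: 31800 nM

In a functional assay on cells (Leukemia cell, Homo sapiens) for cytotoxicity, read by sulforhodamine B assay, with a stated time of 48 h (a higher number here means a weaker inhibitor of growth, a lower number a stronger inhibitor of growth), compound 1 gives 5030 nM and compound 3 gives 31800 nM. The move between them is a group of 8 heavy atoms (6 carbon, 2 oxygen; one six-membered non-aromatic ring of carbon only) in place of a group of 8 heavy atoms (6 carbon, 2 oxygen; one six-membered aromatic ring of carbon only), on an aromatic carbon, and in this assay it made a step of a 6.3-fold higher number from compound 1 to compound 3 (0.80 log units; beyond the scatter). Compound 2, in this assay, gives 93600 nM, the highest of the three numbers; how its core differs from that of compound 1 is not broken down here.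

Compound 4 `CC(=O)NS(=O)(=O)c1ccc(-n2nc(-c3ccccc3)cc2C2=CC(=O)C=CC2=O)cc1` has not been measured in this assay. It differs from compound 2 by a group of 8 heavy atoms (6 carbon, 2 oxygen; one six-membered non-aromatic ring of carbon only) in place of a group of 8 heavy atoms (6 carbon, 2 oxygen; one six-membered aromatic ring of carbon only), on an aromatic carbon. Around the place, compound 2 has a phenyl group where compound 1 has a 4-chlorophenyl group, and the neighbouring ring atom bears a large group rather than a named 4-sulfamoylphenyl group, so this is the same kind of change, not the same. Within the data shown here, a step of about a 4.8-fold higher number from compound 2 to compound 4 (0.68 log units; beyond the scatter) is expected, resting on the single step of a 6.3-fold higher number from compound 1 to compound 3 (0.80 log units; beyond the scatter). Compound 4 is therefore estimated at 450000 nM, between 150000 nM and 1300000 nM, with a real chance that only a limit is reported.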

Compound 4, concentration for 50% growth inhibition: 57800 nM
Compound 4: the middle estimate sits 7.8-fold (0.89 log units) above what was measured; measured number outside the range, below it.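

On the core of compound 2, putting the quinone ring in place of the 2,5-dihydroxyphenyl group gave a 1.6-fold lower number from compound 2 to compound 4 (0.21 log units; within the scatter) in this assay, so on this core the exchange produces no readable difference. The change therefore did not carry over with the same size from one core to the other: the same change on two cores in this assay, a 6.3-fold higher number (0.80 log units; beyond the scatter) from compound 1 to compound 3 and a 1.6-fold lower number (0.21 log units; within the scatter) from compound 2 to compound 4, 10-fold (1.01 log units) apart, beyond the scatter of two such steps

The two cores differ in more than one place, with an acetyl group on the sulfonamide and a phenyl group in place of 4-chlorophenyl, so these two pairs show that the outcome of the exchange depends on the core but not which of those differences is responsible, and two pairs give no general rule for the series.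

The compounds shown leave open how the exchange behaves when only the acetyl group or only the chlorine differs. They also leave open what a methoxy group, an amine or a carboxylic acid on the ring at this place would do in this assay.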